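Fluoro in place of methyl: three measured, one pending

The source may hold more compounds than are shown below. What is called first, only, known or untested is meant among the compounds shown, and "the series" means these compounds.

Compound 1 `Cc1ccc(S(=O)(=O)NC(=O)/C=C/c2ccc(F)cc2)cc1` gives 4.8 ug/mL in a functional assay on B16-F10 cells (Mus musculus) for antiproliferative activity, read by ELISA and MTT assay, with a stated time of 48 h; on this read-out lower numbers stand for stronger inhibition and higher numbers for weaker inhibition. Compound 2 `O=C(/C=C/c1ccc(F)cc1)NS(=O)(=O)c1ccc(F)cc1` differs from it by fluoro in place of methyl on an aromatic carbon, and in this assay compound 2 gives 0.8 ug/mL; the step is a 6.0-fold lower number from compound 1 to compound 2 (0.78 log units; beyond the scatter). Compound 3 `Cc1ccc(S(=O)(=O)NC(=O)/C=C/c2ccc([N+](=O)[O-])cc2)cc1` carries a different core, its difference from compound 1 being (nitro in place of fluoro on an aromatic carbon); in this assay compound 3 gives 13.5 ug/mL, a step of a 2.8-fold higher number from compound 1 to compound 3 (0.45 log units; beyond the scatter), and it stands at the highest of the three numbers.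

Compound 4 `O=C(/C=C/c1ccc([N+](=O)[O-])cc1)NS(=O)(=O)c1ccc(F)cc1` has not been measured. Its difference from compound 3, (fluoro in place of methyl on an aromatic carbon), is the same change as that from compound 1 to compound 2, with the place described in the same words for both pairs. Among the measured compounds shown here, only one measured instance of this change exists, so its transfer to the core of compound 3 is untested. For compound 4 a step of a 4.5-fold lower number from compound 3 to compound 4 (0.65 log units; beyond the scatter) is expected, kept somewhat smaller than the measured one because a 6.0-fold lower number from compound 1 to compound 2 (0.78 log units; beyond the scatter) rests on a single pair. Compound 4 is therefore estimated at 3 ug/mL, with a range from 1.2 ug/mL to 8 ug/mL.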

Compound 4, half-maximal inhibitory concentration: 2.2 ug/mL
Compound 4: the middle estimate sits 1.4-fold (0.13 log units) above what was measured; the measured number falls inside the stated range.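

In this assay, fluoro in place of methyl on an aromatic carbon carries over to the core of compound 3, where the new step is a 6.1-fold lower number from compound 3 to compound 4 (0.79 log units; beyond the scatter) and matches the earlier one: the same change on two cores in this assay, a 6.0-fold lower number (0.78 log units; beyond the scatter) from compound 1 to compound 2 and a 6.1-fold lower number (0.79 log units; beyond the scatter) from compound 3 to compound 4, 1.0-fold (0.01 log units) apart, within the scatter of two such steps. Nitro in place of fluoro gives the same picture, with a 2.8-fold higher number from compound 2 to compound 4 (0.44 log units; beyond the scatter), so within these compounds the two changes combine without visible interaction: the same change on two cores in this assay, a 2.8-fold higher number (0.45 log units; beyond the scatter) from compound 1 to compound 3 and a 2.8-fold higher number (0.44 log units; beyond the scatter) from compound 2 to compound 4, 1.0-fold (0.01 log units) apart, within the scatter of two such steps. Among the compounds shown here, these agreements are not independent support, since both comparisons come from the same closed set of four compounds, and they show transfer between only two cores in one cell line, not a rule for the series.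

From the compounds shown here alone, whether the step holds with a chloro or methoxy group in place of fluoro, or with an amine or a carboxylic acid in place of nitro, remains open. Also open, going by these compounds, is whether the two changes stay additive on a core with a longer chain in place of the alkene linker.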